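Chloro added to the benzamide ring of compound 2

This account rests on a few compounds, and the source may have more. Where it says the series, first, only, none or still open, it means among the compounds named here.

The series shares one core, here carried by compound 2 `COc1cc(-c2nn(-c3cccc(NC(=O)c4cccc(C(F)(F)F)c4)c3)cc2-c2ccncc2)ccc1Cl` and by compound 1 `COc1cc(-c2nn(-c3cccc(NC(=O)Nc4cc(C(F)(F)F)cc(C(F)(F)F)c4)c3)cc2-c2ccncc2)ccc1Cl`. In a functional assay on T47D cells (Homo sapiens) for inhibition, read by sulforhodamine B assay, with a stated time of 48 h (on this read-out lower numbers stand for stronger inhibition of growth and higher numbers for weaker inhibition of growth), compound 2 gives 2550 nM. In the same assay compound 1 gives 1550 nM. Compound 2 and compound 1 differ by less than the usual scatter of repeated measurements, so the two stand together and neither can be set above the other.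

Compound 3 `COc1cc(-c2nn(-c3cccc(NC(=O)c4ccc(Cl)c(C(F)(F)F)c4)c3)cc2-c2ccncc2)ccc1Cl` has not been measured in this assay. It differs from compound 2 in one place: chloro in place of hydrogen on an aromatic carbon, ortho to a trifluoromethyl group and para to a large group, so that 3-(trifluoromethyl)phenyl becomes 4-chloro-3-(trifluoromethyl)phenyl.

Within the data shown here, no measured pair in this set shows the effect of this change, so the expectation rests only on compound 2. The step from compound 2 to compound 3 is expected to be small, if anything toward a lower number, and not clearly beyond the scatter, a 1.6-fold lower number from compound 2 to compound 3 (0.20 log units; within the scatter). In this assay compound 3 is therefore estimated at 1600 nM, within a range from 600 nM to 4500 nM.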

Compound 3, concentration for 50% growth inhibition: 2050 nM
Compound 3: middle estimate off by 1.3-fold (0.11 log units), on the low side, within the range that was stated.
By their numbers in this assay, from the lowest: compounds 1, 3 and 2 (each within the scatter of the next).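

In this assay, chloro in place of hydrogen on an aromatic carbon, ortho to a trifluoromethyl group and para to a large group, gives a 1.2-fold lower number from compound 2 to compound 3 (0.09 log units; within the scatter), so compound 2 and compound 3 stand together. Among these compounds, this is the first step in the set between measured compounds that differ in one place, and it shows that turning 3-(trifluoromethyl)phenyl into 4-chloro-3-(trifluoromethyl)phenyl leaves the growth-inhibition read-out indistinguishable from that of the parent, which compound 1 and compound 2 alone could not show. No measurement available here accounts for this result.

A single chloro step says only that this one substituent at this position makes no difference that can be told from the scatter, and it leaves open whether a methoxy group, an amine or a carboxylic acid in its place would give a step beyond the scatter. It also leaves open whether the same chloro would give a similarly small step on the 3-(trifluoromethyl)phenyl ring of a compound with a urea in place of the amide.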